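Replacing a Chain Substituent with a Small Ring

The compounds below may be only part of what the source reports. "The series", "measured", "known", "first", "only" and "open" are said of these compounds alone.

compound 1 `CCCn1c(Cc2cc(OC)c(OC)c(OC)c2)nc2c(N)nc(F)nc21`: 25100 nM
compound 2 `COc1cc(Cc2nc3c(N)nc(F)nc3n2CCOC(C)C)cc(OC)c1OC`: 15800 nM

In a functional assay on MCF7 cells (Homo sapiens) for antiproliferative activity (on this read-out lower numbers stand for stronger inhibition and higher numbers for weaker inhibition), compound 2 gives 15800 nM, and compound 1 gives 25100 nM; the step between them, a 1.6-fold lower number from compound 1 to compound 2 (0.20 log units; within the scatter), stays within the scatter, so compound 2 stands level with compound 1 on the numbers shown. Compound 3 `COc1cc(Cc2nc3c(N)nc(F)nc3n2CC2CCC2)cc(OC)c1OC` differs from compound 2 by cyclobutyl in place of isopropoxymethyl on a saturated chain carbon bound to an aromatic nitrogen. Within the data shown here, the only measured step, a 1.6-fold lower number from compound 1 to compound 2 (0.20 log units; within the scatter), altered the same chain further out without a change beyond the scatter. Among the measured compounds shown here, no measured step exchanges this chain for a ring. For compound 3 the expected step is a 1.0-fold higher number from compound 2 to compound 3 (0.01 log units; within the scatter), none beyond the scatter. Compound 3 is therefore estimated at 16000 nM, between 5000 nM and 50000 nM.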

Compound 3, half-maximal inhibitory concentration: 40700 nM
Compound 3: the middle estimate sits 2.5-fold (0.41 log units) below what was measured; the range from low to high includes it.
By their numbers in this assay, from the lowest: compounds 2, 1 and 3 (each within the scatter of the next, the first and the last beyond it).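

In this assay, among these compounds, cyclobutyl in place of isopropoxymethyl gives the first step at this position that goes beyond the scatter, a 2.6-fold higher number from compound 2 to compound 3 (0.41 log units; beyond the scatter), so this ring does not simply stand in for the ether chain. Set against the ethyl it replaces in compound 1, the same ring gives a 1.6-fold higher number from compound 1 to compound 3 (0.21 log units; within the scatter), which stays within the scatter. Nothing measured here explains this difference between the two steps.

The compounds shown leave open whether the ring or the missing ether oxygen accounts for the modest step. They also leave open how a cyclopentyl ring or a chain ending in an amine would behave on this carbon.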